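Adding a Second Chloro to the Shared Core

This account rests on a few compounds, and the source may have more. Where it says the series, first, only, none or still open, it means among the compounds named here.

Of the compounds shown here, three have been measured in a functional assay on HCT-15 cells (Homo sapiens) for cytotoxicity, read by sulforhodamine B assay, with a stated time of 48 h; on this read-out higher numbers stand for weaker inhibition of growth and lower numbers for stronger inhibition of growth. Compound 1 `ClCc1ccc(Cn2cnc3c(Cl)ncnc32)cc1` gives 1950 nM. Among the measured compounds shown here, compound 2 `Nc1nc(Cl)c2ncn(Cc3ccccc3CCl)c2n1` gives 2700 nM, a number that sits within the scatter of the one for compound 1, so the two cannot be told apart. Compound 3 `ClCc1cccc(Cn2cnc3nc(Cl)nc(Cl)c32)c1` gives 950 nM, which is the lowest number of the three and lies beyond the scatter from compound 1; compound 1 therefore holds the second-highest number of the set, close to compound 2 and clearly apart from compound 3.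

Compound 4 `ClCc1ccc(Cn2cnc3c(Cl)nc(Cl)nc32)cc1` has not yet been measured in this assay. It differs from compound 1 in one place: chloro in place of hydrogen on an aromatic carbon. For the measured compounds named here, no directly measured pair shows this single change on its own, so its effect must be guessed. Compound 3, which also carries two chloro groups on the shared core though with a different arrangement of the side chain, shows the lower number 950 nM, and on that basis a modest step downward, at the edge of the scatter, is expected from compound 1 to compound 4, namely a 1.8-fold lower number from compound 1 to compound 4 (0.25 log units; within the scatter). Compound 4 is accordingly estimated at 1100 nM, with a plausible range from 500 nM to 2500 nM.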

Compound 4, concentration for 50% growth inhibition: 1860 nM
Compound 4: middle estimate off by 1.7-fold (0.23 log units), on the low side; measured number inside the range.
By their numbers in this assay, from the lowest: compounds 3, 4, 1 and 2 (each within the scatter of the next, the first and the last beyond it).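

Among the compounds shown here, the pair of compound 1 and compound 4 gives the first direct reading of this change in this assay: chloro in place of hydrogen on an aromatic carbon, at the position between two ring nitrogen atoms, gives a 1.0-fold lower number from compound 1 to compound 4 (0.02 log units; within the scatter) and so the two compounds cannot be told apart. On this single pair, then, a chloro at this position makes no readable difference to growth inhibition, although the shared core now carries a second chloro group. Nothing available here explains this result.

As far as these compounds go, whether a methyl, a methoxy or a nitrile at the same position would also leave the number within the scatter remains open. From the compounds shown here alone, it is also open whether this chloro step would read the same with the side chain arranged differently.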